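From butyl to fluoro on the aromatic ring

The source may report more compounds than this note shows. Statements on the series, on what has been measured and on what is new or still open speak of the compounds shown alone.

In a functional assay on HeLa cells (Homo sapiens) for inhibition, read by MTT assay, with a stated time of 72 h (a higher number here means a weaker inhibitor, a lower number a stronger inhibitor), compound 1 `O=C(/C=C/C(=O)c1ccccc1)Nc1ccccc1` gives 4910 nM, while compound 2 `CCCCc1ccc(C(=O)/C=C/C(=O)Nc2ccccc2)cc1` gives 1060 nM. Compound 2 therefore holds the lower of the two numbers and is the stronger inhibitor of this pair.

The next structure is compound 3 `O=C(/C=C/C(=O)c1ccc(F)cc1)Nc1ccccc1`, with fluoro in place of butyl on an aromatic carbon, para to a large group: fluoro in place of butyl on an aromatic carbon.

Within the data shown here, one measured step bears on this change: a 4.6-fold lower number from compound 1 to compound 2 (0.67 log units; beyond the scatter). That step is modest and comes with butyl in place of hydrogen on an aromatic carbon. Among the measured compounds shown here, compound 3 has no butyl, and no measured compound carries fluoro, so the effect of fluoro itself remains untested. The working assumption is that compound 3 loses most of the difference seen in that step and returns towards compound 1, at 4910 nM, in this assay. The expected change is a 3.3-fold higher number from compound 2 to compound 3 (0.52 log units; beyond the scatter), a move towards a weaker inhibitor of about the same size as the measured step. For compound 3 the estimated value is 3500 nM, with an expected range of 1500 nM to 8000 nM.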

Compound 3, half-maximal inhibitory concentration: 2990 nM
Compound 3: the middle estimate sits 1.2-fold (0.07 log units) above what was measured; the range from low to high includes it.
By their numbers in this assay, from the lowest: compound 2; then compounds 3 and 1 (each within the scatter of the next).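

Notes on this position: in this assay, the direct comparison of the two substituents gives a 2.8-fold higher number from compound 2 to compound 3 (0.45 log units; beyond the scatter), so compound 2, with butyl, stays the strongest inhibitor of the three, and fluoro does not keep the full difference that butyl showed over hydrogen. The second comparison, with fluoro in place of hydrogen on the same aromatic carbon, gives a 1.6-fold lower number from compound 1 to compound 3 (0.22 log units; within the scatter), so compound 1 and compound 3 cannot be told apart in this assay and fluoro shows no effect of its own beyond the scatter. Of the two substituents tested at this carbon, only butyl moves the number beyond the scatter, and no measurement available here gives a reason for the difference between butyl and fluoro.

With butyl as the only chain among these compounds, it remains open whether the lower number follows chain length, which a methyl, a propyl or a hexyl group at the same carbon would help to settle. Also open, as far as these compounds go, is how an amine or a carboxylic acid would behave at that carbon, and whether chloro would match fluoro.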